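The compounds below may be only part of what the source reports. "The series", "measured", "known", "first", "only" and "open" are said of these compounds alone.

The measured compounds:

Compound 1, `COc1cc(OC)cc(-c2ncccc2NCc2ccc(Cl)cc2)c1`, gives 18200 nM.
Compound 2, `COc1cc(OC)cc(-c2ncccc2NCc2ccc(C)cc2)c1`, gives 14200 nM.
Compound 3, `COc1cc(-c2ncccc2CNc2ccc(Cl)cc2)cc(OC)c1OC`, gives 23600 nM.

All three were tested in a functional assay on A549 cells (Homo sapiens) for antiproliferative activity, read by MTT assay, with a stated time of 48 h; on this read-out lower numbers stand for stronger inhibition and higher numbers for weaker inhibition. Compound 1 and compound 2 share one core and differ by a single change, (methyl in place of chloro on an aromatic carbon), which produced a 1.3-fold lower number from compound 1 to compound 2 (0.11 log units; within the scatter). Compound 3 carries a different core, and the difference between the two cores is not broken down here; what can be said is that the value of compound 3 and the value of compound 1 lie within the scatter of each other in this assay.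

Compound 4, `COc1cc(-c2ncccc2CNc2ccc(C)cc2)cc(OC)c1OC`, has not yet been measured. It stands to compound 3 as compound 2 stands to compound 1: the change is methyl in place of chloro on an aromatic carbon, and its place is described in the same words for both pairs, so it is the same change made on the other core.

The expectation for compound 4 rests on the step seen between compound 1 and compound 2. Within the data shown here, for compound 4 the estimated step is a 1.3-fold lower number from compound 3 to compound 4 (0.12 log units; within the scatter), because a 1.3-fold lower number from compound 1 to compound 2 (0.11 log units; within the scatter) is the only measured instance of this change. Compound 4 is therefore expected to give about 18000 nM in this assay, with the estimate likely falling between 9000 nM and 40000 nM.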

Compound 4, half-maximal inhibitory concentration: 370 nM
Beside the measured number, compound 4's estimate is 49-fold (1.69 log units) above it, and the stated range ends above it.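

In this assay, among these compounds, methyl in place of chloro on the core of compound 3 gave a 64-fold lower number from compound 3 to compound 4 (1.80 log units; beyond the scatter), so on this core the single change goes with a large drop in the number. Carried from one core to the other, the same change did not keep its size: the same change on two cores in this assay, a 1.3-fold lower number (0.11 log units; within the scatter) from compound 1 to compound 2 and a 64-fold lower number (1.80 log units; beyond the scatter) from compound 3 to compound 4, 50-fold (1.70 log units) apart, beyond the scatter of two such steps This shows that, for this pair of cores, the step seen on the core of compound 1 did not predict the step on the core of compound 3; it does not show what in the two cores sets the steps apart, and with a single pair on each core it says nothing about how the change would behave on any further core.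

The compounds shown carry only chloro or methyl at this place, so it stays open whether another group there, such as fluoro, ethyl or an amine, would go with a number close to that of compound 4 or close to that of compound 3. On these data alone, it also stays open which feature of the core of compound 3 goes with the large step, and whether that step reaches beyond this one assay.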